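Replacing a methoxyethyl amide substituent with a bare amino group

The source may report more compounds than this note shows. Statements on the series, on what has been measured and on what is new or still open speak of the compounds shown alone.

Measured so far:
Compound 1 `CN1CCN(C(=O)c2cc(-c3ccc(Cl)cc3Cl)n[nH]2)CC1`: 828 nM
Compound 2 `COCCNC(=O)c1cc(-c2ccc(Cl)cc2Cl)n[nH]1`: 46 nM

Of the two measured compounds, compound 2 gives the lower number in an assay on isolated protein for inhibition of alkaline phosphatase, tissue-nonspecific isozyme (Homo sapiens) (on this read-out higher numbers stand for weaker inhibition and lower numbers for stronger inhibition), and the step of an 18-fold lower number from compound 1 to compound 2 (1.26 log units; beyond the scatter) shows how much the group on the carbonyl carbon can matter. Compound 3 `NNC(=O)c1cc(-c2ccc(Cl)cc2Cl)n[nH]1` keeps the shared core and the amide, but differs from compound 2 in that (amino in place of 2-methoxyethyl on an amide-type nitrogen); cut one bond further out, the change reads as aminoamino in place of (2-methoxyethyl)amino.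

Among the compounds with values here, no measured step covers this exact change. Within the data shown here, the only step available, from a 4-methylpiperazin-1-yl to a (2-methoxyethyl)amino group, was large, which shows that this position is sensitive to what sits on it, but it gives no direction for removing the 2-methoxyethyl chain. The expectation for compound 3 is therefore a moderate shift towards a higher number, a 3.3-fold higher number from compound 2 to compound 3 (0.51 log units; beyond the scatter), with wide uncertainty. The estimate for compound 3 in this assay is 150 nM, with a range from 40 nM to 600 nM.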

Compound 3, half-maximal inhibitory concentration: 44 nM
Beside the measured number, compound 3's estimate is 3.4-fold (0.53 log units) above it; measured number inside the range.
By their numbers in this assay, from the lowest: compounds 3 and 2 (each within the scatter of the next); then compound 1.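

In this assay, the step of a 1.0-fold lower number from compound 2 to compound 3 (0.02 log units; within the scatter) means that compound 2 and compound 3 cannot be told apart, even though a single amino group has taken the place of the 2-methoxyethyl chain on the amide-type nitrogen. The chain's 4 heavy atoms are therefore not needed to reach this level of inhibition, and aminoamino in place of 4-methylpiperazin-1-yl on a carbonyl carbon gives a large step of its own, a 19-fold lower number from compound 1 to compound 3 (1.27 log units; beyond the scatter), much like the earlier 18-fold lower number from compound 1 to compound 2 (1.26 log units; beyond the scatter). Nothing here explains why these two different groups give such similar numbers.

Still open, on these data alone, is how a plain methyl group, or a longer chain ending in a carboxylic acid, would read on this nitrogen. Also open, as far as these compounds go, is how a dimethylamino group on the carbonyl carbon would compare with the 4-methylpiperazin-1-yl group.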